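From 3-chlorophenyl to 4-bromophenyl at the assay limit

A few compounds are considered here, and "the series" means these few. Any claim that something is new, unique, unknown or untested is made for them only; others in the source may bear on it.

- Compound 1 `O=C(Nc1ccc(Cl)cc1)N1CCC[C@H]1c1nc(-c2ccccc2)no1` gives > 50000 nM as a limit
- Compound 2 `O=C(Nc1ccc(Cl)cc1)N1CCC[C@H]1c1nc(-c2ccccc2Cl)no1` gives > 50000 nM as a limit
- Compound 3 `O=C(Nc1ccc(Cl)cc1)N1CCC[C@H]1c1nc(-c2cccc(Cl)c2)no1` gives > 50000 nM as a limit

In an ADME assay on MCF-10A cells (Homo sapiens) for inhibition, with a stated time of 48 h (on this read-out lower numbers stand for stronger inhibition and higher numbers for weaker inhibition), compound 3 gives > 50000 nM as a limit, not a number. All the measured compounds rest on the same ceiling (the limit of > 50000 nM in this assay, at which 3 of the 3 values shown sit). Compound 4 `O=C(Nc1ccc(Cl)cc1)N1CCC[C@H]1c1nc(-c2ccc(Br)cc2)no1` carries 4-bromophenyl in place of 3-chlorophenyl on an aromatic carbon. Within the data shown here, three measured steps bear on this change: (a step that the two limits leave unreadable from compound 1 to compound 2), (a step that the two limits leave unreadable from compound 1 to compound 3) and (a step that the two limits leave unreadable from compound 2 to compound 3). None of them has a readable size, so no step beyond the scatter, in either direction, is expected in this assay here. The expected change is (a number no higher from compound 3 to compound 4 (the limit leaves the size open)). Compound 4 is estimated at 50000 nM within a range from 25000 nM to 100000 nM and is expected to give only a limit again.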

Compound 4, half-maximal inhibitory concentration: > 50000 nM
Compound 4: a limit, no number (the forecaster's own chance of this, stated with the estimate: 85%); the middle value lies on the limit itself.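

Compound 4 is again only a limit, as are compounds 1, 2 and 3, so no step among these four compounds can be read: the limit of > 50000 nM in this assay, at which 4 of the 4 values shown sit.

The compounds shown leave open how strongly any of them inhibits, and whether any change to the shared core would give a measurable number.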